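A few compounds are considered here, and "the series" means these few. Any claim that something is new, unique, unknown or untested is made for them only; others in the source may bear on it.

Three compounds have numbers in an ADME assay (liver) for metabolic stability, with Liver microsome (Homo sapiens) as the target, read by LC-MS, using microsomes, with a stated time of 30 min, tested at 4 uM; a higher number here means that more of the compound is left, a lower number that less of the compound is left. Compound 1 `COCCn1c(-c2ccccc2Cl)nc2c(N3CCN4C(=O)CCC4C3)nc(C)nc21` gives 32%, compound 2 `Cc1nc(N2CCN(C)CC2)c2nc(-c3ccccc3C(F)(F)F)n(C3CCOCC3)c2n1` gives 24%, and compound 3 `Cc1nc(N2CCN(C)CC2)c2nc(-c3cccc(C(F)(F)F)c3)n(C3CCOCC3)c2n1` gives 19%. Compound 3 therefore stands within the scatter of compound 2 and lower than compound 1 by a margin beyond the scatter.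

The next compound, compound 4 `COc1cccc(-c2nc3c(N4CCN(C)CC4)nc(C)nc3n2C2CCOCC2)c1`, keeps everything in compound 3 except one group: methoxy in place of trifluoromethyl on an aromatic carbon. This puts methoxy in place of trifluoromethyl on an aromatic carbon, meta to a large group. Among the measured compounds shown here, only one measured step bears on this change, and it relocates the trifluoromethyl group rather than replacing it. That step, 3-(trifluoromethyl)phenyl in place of 2-(trifluoromethyl)phenyl, is a number 5 percentage points lower from compound 2 to compound 3 (within the scatter). For the measured compounds named here, no measured compound carries methoxy, so the data give no direct size for this exchange, and no step beyond the scatter is expected in this assay. The expected step is a number 1 percentage points higher from compound 3 to compound 4 (within the scatter). For compound 4 the estimated value is 20%, with an expected range from 8% to 35%.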

Compound 4, percent of the compound remaining: 40%
For compound 4 the middle estimate is 20 percentage points below the measured one; measured number above the stated range.
By their numbers in this assay, from the lowest: compounds 3, 2, 1 and 4 (each within the scatter of the next, the first and the last beyond it).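

In this assay, among the compounds shown here, the identity of the group on this aromatic carbon proves to count for more than anything the earlier compounds showed: methoxy in place of trifluoromethyl gives a number 21 percentage points higher from compound 3 to compound 4 (beyond the scatter) and is the first single exchange to clear the scatter, while relocating trifluoromethyl gave only a number 5 percentage points lower from compound 2 to compound 3 (within the scatter) and did not. The 3-methoxyphenyl group also stands clear of the other trifluoromethyl isomer, with a number 16 percentage points higher from compound 2 to compound 4 (beyond the scatter) as the printed step, so the rise does not depend on which of the two trifluoromethyl compounds serves as the reference. Nothing at hand accounts for this rise.

Going by these compounds, it remains open whether an ethoxy, a hydroxyl or a nitrile on the same carbon would give a step of like size. The compounds shown also leave open whether methoxy would raise the number on the core of compound 1.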